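Swapping fluoro for bromo on a halogenated hydroxybenzamide

The compounds below may be only part of what the source reports. "The series", "measured", "known", "first", "only" and "open" are said of these compounds alone.

Compound 1 `O=C(Nc1ccc(Br)cc1F)c1cc(F)ccc1O`: 1860 nM
Compound 2 `O=C(Nc1ccc(Cl)cc1F)c1ccccc1O`: 10000 nM
Compound 3 `O=C(Nc1ccc(I)cc1F)c1cc(F)ccc1O`: 1570 nM

In a functional assay on RAW264.7 cells (Mus musculus) for inhibition, read by microscopy, with a stated time of 4 days, in the presence of a further agent that is not named here (a lower number here means a stronger inhibitor, a higher number a weaker inhibitor), compound 3, at 1570 nM, stands level with compound 1 within the scatter, and both show lower numbers than compound 2. Compound 4 `O=C(Nc1ccc(I)cc1F)c1cc(Br)ccc1O` differs from compound 3 by bromo in place of fluoro on an aromatic carbon, with bromo in place of fluoro on an aromatic carbon, para to a hydroxy group. Among the compounds with values here, no measured step covers this exchange. Compound 2 differs from compound 1 in two places, so it isolates nothing. The nearest guide is compound 3, reached through a 1.2-fold lower number from compound 1 to compound 3 (0.07 log units; within the scatter), a halogen exchange at another place. The expected step is small, no clear move beyond the scatter: a 1.3-fold lower number from compound 3 to compound 4 (0.12 log units; within the scatter). Compound 4 is estimated at 1200 nM, with an expected range of 450 nM to 3200 nM.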

Compound 4, half-maximal inhibitory concentration: 1930 nM
Beside the measured number, compound 4's estimate is 1.6-fold (0.21 log units) below it; the measured number falls inside the stated range.
By their numbers in this assay, from the lowest: compounds 3, 1 and 4 (each within the scatter of the next); then compound 2.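

In this assay, the exchange of fluoro for bromo para to a hydroxy group leaves the number within the scatter (a 1.2-fold higher number from compound 3 to compound 4 (0.09 log units; within the scatter)). On the core of compound 3, this place therefore accepts either halogen without a readable change, which the earlier halogen exchange, made at another place, could not show. Nothing available explains this tolerance. The compounds shown leave open whether a group other than a halogen, such as an amine or a carboxylic acid, would be tolerated at this place. They also leave open how a methoxy group would behave there.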